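Phenyl for butyl on the hydroxyacyl arm of compound 1

The source may hold more compounds than are shown below. What is called first, only, known or untested is meant among the compounds shown, and "the series" means these compounds.

Compound 1, `CCCC[C@@H](O)C(=O)N1N=CC[C@H]1C(=O)NCc1cc(Cl)ccc1-n1cnnn1`: 240 nM
Compound 2, `CC(C)(C)[C@@H](O)C(=O)N1C[C@@H]2C[C@@H]2[C@H]1C(=O)NCc1cc(Cl)ccc1-n1cnnn1`: 66 nM

Of the compounds shown here, two have been measured in a functional assay (plasma) for inhibition, with Rattus norvegicus as the target; a lower number here means a stronger inhibitor, a higher number a weaker inhibitor. Compound 1 gives the higher of the two numbers, and the gap to compound 2 lies beyond the usual scatter, so compound 1 is the weaker inhibitor of the pair. For the measured compounds named here, compound 2 also differs from compound 1 in its core, so no single step between them can be isolated.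

Compound 3, `O=C(NCc1cc(Cl)ccc1-n1cnnn1)[C@@H]1CC=NN1C(=O)[C@H](O)c1ccccc1`, keeps the core of compound 1 and changes only the hydroxyacyl arm: phenyl in place of butyl on a saturated chain carbon bound to a carbonyl carbon and an oxygen on a saturated carbon. Going by the values given here, no measured pair shows this change on its own. Compound 3 is expected to give a somewhat lower number in this assay than compound 1, a step of a 2.0-fold lower number from compound 1 to compound 3 (0.30 log units; within the scatter) of modest size, though it may fall within the scatter. The estimate for compound 3 in this assay is 120 nM, with a range from 40 nM to 400 nM.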

Compound 3, half-maximal inhibitory concentration in the Rattus norvegicus assay: 120 nM
Compound 3: the middle estimate sits on the measured number at the digits printed; low and high end bracket the measured number.
By their numbers in the Rattus norvegicus assay, from the lowest: compounds 2, 3 and 1 (each within the scatter of the next, the first and the last beyond it).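

In the Rattus norvegicus assay, phenyl in place of butyl on a saturated chain carbon bound to a carbonyl carbon and an oxygen on a saturated carbon gives a 2.0-fold lower number from compound 1 to compound 3 (0.30 log units; within the scatter) and so shows that this position can carry a six-membered aromatic ring instead of an open chain without a step beyond the scatter. In a physicochemical assay for solubility, measured as kinetic solubility, at pH 6.8 (a lower number here means a less soluble compound, a higher number a more soluble compound), compound 1 gives 59000 nM and compound 3 gives 98000 nM as the same change reads as a 1.7-fold higher number from compound 1 to compound 3 (0.22 log units; within the scatter) in that assay, so neither read-out separates the two compounds. Nothing at hand explains these numbers.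

The compounds shown leave open how a cyclohexyl group or a benzyl group would read at this carbon. They also leave open whether phenyl would give a like step on the core of compound 2.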